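The source may hold more compounds than are shown below. What is called first, only, known or untested is meant among the compounds shown, and "the series" means these compounds.

Two measured compounds share a core. In an assay on isolated protein for inhibition of Amine oxidase [flavin-containing] A (Homo sapiens), read by spectrophotometry (a higher number here means a weaker inhibitor, a lower number a stronger inhibitor), compound 1 `COc1ccc(/C=N/Nc2nc3ccccc3nc2Cc2ccccc2)cc1` gives 63 nM, the higher of the two numbers. Compound 2 `C/C(=N\Nc1nc2ccccc2nc1Cc1ccccc1)c1ccc(O)cc1` gives 2.8 nM, a gap beyond the usual scatter. Compound 3 `Brc1cccc(/C=N/Nc2nc3ccccc3nc2Cc2ccccc2)c1` has not been measured; it differs from compound 1 by 3-bromophenyl in place of 4-methoxyphenyl on a carbon with a double bond to nitrogen. Among the compounds with values here, no measured pair shows this exact change, so the direction is uncertain. A modest move toward a higher number is expected from compound 1 to compound 3, as a 2.4-fold higher number from compound 1 to compound 3 (0.38 log units; beyond the scatter), possibly beyond the scatter. For compound 3 the estimated result in this assay is 150 nM, with a range from 40 nM to 600 nM.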

Compound 3, half-maximal inhibitory concentration: 9.8 nM
The estimate for compound 3 lay 15-fold (1.18 log units) above the measured number, outside the stated range (below it).
By their numbers in this assay, from the lowest: compound 2; then compound 3; then compound 1.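

In this assay, 3-bromophenyl in place of 4-methoxyphenyl on a carbon with a double bond to nitrogen gives a 6.4-fold lower number from compound 1 to compound 3 (0.81 log units; beyond the scatter), so this position accepts a real change of group and the number can fall. The entering group has no hydrogen-bond acceptor, so compound 3 reaches its low number without one in this group. Nothing available explains the drop.

This one step swaps the substituent and its place on the ring together, leaving the two changes unseparated. From the compounds shown here alone, how a phenyl carrying an amine or a carboxylic acid would read here remains open.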